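A few compounds are considered here, and "the series" means these few. Any claim that something is new, unique, unknown or untested is made for them only; others in the source may bear on it.

Two compounds share one core and differ only on the fused aromatic ring. Compound 1 `CC#C[C@@H](CC(=O)O)c1ccc(OC[C@H]2COc3cccc(Cl)c3O2)cc1` carries a chloro there, and in a functional assay on HEK293 cells for agonist activity at Free fatty acid receptor 1 (Homo sapiens), read by fluorescence and calcium flux, with a stated time of 10 min (a lower number here means a smaller maximal response, a higher number a larger maximal response), compound 1 reaches 95%. Compound 2 `CC#C[C@@H](CC(=O)O)c1ccc(OC[C@H]2COc3ccccc3O2)cc1` has hydrogen in place of that chloro; in this assay compound 2 reaches 70%, the lower of the two numbers. Among the measured compounds shown here, the only measured step, a number 25 percentage points lower from compound 1 to compound 2 (beyond the scatter), is a modest drop beyond the scatter.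

Compound 3 `CC#C[C@@H](CC(=O)O)c1ccc(OC[C@H]2COc3ccc(C#N)cc3O2)cc1` is the next step from compound 2: cyano in place of hydrogen on an aromatic carbon. For the measured compounds named here, it brings a substituent back onto the fused ring, though a different group, so the chloro step is the only guide and bears on it loosely. Because a number 25 percentage points lower from compound 1 to compound 2 (beyond the scatter) was modest, the step for compound 3 is expected to be modest and upward, a number 10 percentage points higher from compound 2 to compound 3 (within the scatter), though it could fall within the scatter. Compound 3 is therefore estimated at 80% in this assay, with a range of 60% to 98%.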

Compound 3, largest response reached (Emax), in percent of the reference or control that the assay uses: 60%
For compound 3 the middle estimate is 20 percentage points above the measured one; measured number inside the range.
By their numbers in this assay, from the lowest: compounds 3 and 2 (each within the scatter of the next); then compound 1.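

In this assay, cyano in place of hydrogen on this aromatic carbon gives a number 10 percentage points lower from compound 2 to compound 3 (within the scatter), so the maximal responses of these two compounds cannot be told apart. Having a substituent on the fused ring is therefore not enough on its own to shift the response beyond the scatter, and the step seen with chloro does not extend to cyano at this carbon. Nothing measured here explains why the response holds with cyano.

From the compounds shown here alone, it remains open whether a methoxy or a methyl group on this same carbon would also stay within the scatter of compound 2. Also open is what cyano would do on the carbon that carries the chloro in compound 1, since the group and its place are not separated in the compounds shown.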